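Swapping the aromatic group of compound 2

This account rests on a few compounds, and the source may have more. Where it says the series, first, only, none or still open, it means among the compounds named here.

Measured in a functional assay on MCF7 cells (Homo sapiens) for inhibition, with a stated time of 72 h; on this read-out higher numbers stand for weaker inhibition and lower numbers for stronger inhibition:
- Compound 1 `COc1ccccc1-c1ccc(CNc2nc(NC3CCC(N)CC3)nc3c2ncn3C2CCCC2)cc1` gives 303 nM
- Compound 2 `NC1CCC(Nc2nc(NCc3ccc(-c4ccsc4)cc3)c3ncn(C4CCCC4)c3n2)CC1` gives 145 nM
- Compound 3 `CC(C)(O)CNc1nc(NCc2ccc(-c3ccco3)cc2)c2ncn(C3CCCC3)c2n1` gives 15300 nM

Compound 2, at 145 nM, has the lowest number of the three, making it the strongest inhibitor here. Compound 4 `NC1CCC(Nc2nc(NCc3ccc(-c4cccs4)nc3)c3ncn(C4CCCC4)c3n2)CC1` has 6-(thiophen-2-yl)pyridin-3-yl in place of 4-(thiophen-3-yl)phenyl (6-(thiophen-2-yl)pyridin-3-yl in place of 4-(thiophen-3-yl)phenyl on a saturated chain carbon bound to a nitrogen on an aromatic ring). Going by the values given here, one measured step bears on this, since it also swaps an aromatic group: a 2.1-fold lower number from compound 1 to compound 2 (0.32 log units; beyond the scatter), with thiophen-3-yl in place of 2-methoxyphenyl. That step was modest, so only a small change is expected in this assay, and the data favour no direction. The expected change is a 1.1-fold lower number from compound 2 to compound 4 (0.05 log units; within the scatter), which is no clear step beyond the scatter. For compound 4 the estimate is 130 nM, with an expected range from 40 nM to 450 nM.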

Compound 4, half-maximal inhibitory concentration: 92 nM
Compound 4: middle estimate off by 1.4-fold (0.15 log units), on the high side; the measured number falls inside the stated range.
By their numbers in this assay, from the lowest: compounds 4 and 2 (each within the scatter of the next); then compound 1; then compound 3.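

Going by these compounds alone, compound 4 is the only compound here whose six-membered aromatic ring holds a hetero atom, and its thiophene is also attached differently. In this assay these changes together give a 1.6-fold lower number from compound 2 to compound 4 (0.20 log units; within the scatter), so at this position, the number stays within the scatter even with both changes made at once. No available evidence explains this result.

From the compounds shown here alone, because the two changes arrive together, the effect of each alone remains open. So does the outcome of placing an amine or a carboxylic acid on this aromatic group.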